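Changing the acid-like group on a biaryl ester series

This account rests on a few compounds, and the source may have more. Where it says the series, first, only, none or still open, it means among the compounds named here.

Measured so far:
compound 1, `CCOC(=O)c1cccc(-c2ccc(OCC)cc2)c1`: 50000 nM
compound 2, `CCOC(=O)c1cccc(-c2cccs2)c1`: 90000 nM
compound 3, `CCOc1ccc(-c2cccc(S(=O)(=O)NC)c2)cc1`: 200000 nM

In an assay on COS-7 cells for inhibition of patatin-like phospholipase domain-containing protein 2 (Mus musculus) (on this read-out higher numbers stand for weaker inhibition and lower numbers for stronger inhibition), compound 3 gives the highest of the three numbers; compound 2 sits closest to it, and compound 1 is furthest, as shown by a 4.0-fold higher number from compound 1 to compound 3 (0.60 log units; beyond the scatter). Compound 4, `CCOc1ccc(-c2cccc(C(=O)O)c2)cc1`, has not yet been measured. It differs from compound 3 by carboxy in place of methylsulfamoyl on an aromatic carbon. Within the data shown here, no measured pair shows exactly this exchange; the only related step is the one from compound 1 to compound 3, in which a different group replaced the ester. Little guidance therefore exists, and the expected step from compound 3 to compound 4 is a modest one: a 1.3-fold lower number from compound 3 to compound 4 (0.12 log units; within the scatter). Compound 4 is estimated at 150000 nM, within 50000 nM to 500000 nM.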

Compound 4, half-maximal inhibitory concentration: > 200000 nM
Compound 4: no number, only a limit (the forecaster's own chance of this, stated with the estimate: 35%); middle value at least 1.3-fold (0.12 log units) from the limit.
By their numbers in this assay, from the lowest: compounds 1 and 2 (each within the scatter of the next); then compound 3.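

In this assay compound 4 gives only a limit of the assay, > 200000 nM, and not a number. Even so, putting hydrogen in place of the ester's ethyl gives an at least 4.0-fold higher number from compound 1 to compound 4 (0.60 log units; beyond the scatter), so the free carboxy group, like methylsulfamoyl, does not match the ethyl ester at this position. Putting carboxy in place of methylsulfamoyl gives a number no lower from compound 3 to compound 4 (the limit leaves the size open); the size of this step cannot be read, which leaves those two groups unranked.

Still open, from the compounds shown here alone, is whether an amide at this position would do better than these two groups, and whether a longer chain on the ester oxygen would keep or lower the number.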